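A few compounds are considered here, and "the series" means these few. Any claim that something is new, unique, unknown or untested is made for them only; others in the source may bear on it.

Compound 1 `Cc1ccccc1/C(=N/NC(=S)NCCCCCC(=O)NO)c1ccccc1`: 4220 nM
Compound 2 `Cc1ccc(/C(=N/NC(=S)NCCCCCC(=O)NO)c2ccccc2)cc1`: 3150 nM
Compound 3 `O=C(CCCCCNC(=S)N/N=C(\c1ccccc1)c1ccccc1F)NO`: 6010 nM

In a functional assay on K562/A02 cells (Homo sapiens) for antiproliferative activity, read by MTT assay (a higher number here means a weaker inhibitor, a lower number a stronger inhibitor), compound 3 stands level with the other two, as a 1.4-fold higher number from compound 1 to compound 3 (0.15 log units; within the scatter) and a 1.9-fold higher number from compound 2 to compound 3 (0.28 log units; within the scatter) show. Compound 4 `O=C(CCCCCNC(=S)N/N=C(\c1ccccc1)c1ccc([N+](=O)[O-])cc1)NO` carries 4-nitrophenyl in place of 2-fluorophenyl on a carbon with a double bond to nitrogen. The closest evidence comes from changes at that same place, namely a 1.3-fold lower number from compound 1 to compound 2 (0.13 log units; within the scatter) and a 1.9-fold higher number from compound 2 to compound 3 (0.28 log units; within the scatter). Within the data shown here, neither step leaves the scatter, although no measured compound carries 4-nitrophenyl, so this evidence is indirect. No step beyond the scatter is therefore expected in this assay, and the estimated change is a 1.3-fold lower number from compound 3 to compound 4 (0.13 log units; within the scatter). For compound 4, the expected value is 4500 nM, within an estimated range of 1900 nM to 10500 nM.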

Compound 4, half-maximal inhibitory concentration: 4530 nM
Compound 4: middle estimate off by 1.0-fold (0.00 log units), on the low side, within the range that was stated.
By their numbers in this assay, from the lowest: compounds 2, 1, 4 and 3 (each within the scatter of the next).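

In this assay the 4-nitrophenyl group, with its hydrogen-bond acceptors, stays within the scatter of all three earlier groups on this carbon, as a 1.3-fold lower number from compound 3 to compound 4 (0.12 log units; within the scatter) and a 1.4-fold higher number from compound 2 to compound 4 (0.16 log units; within the scatter) and also a 1.1-fold higher number from compound 1 to compound 4 (0.03 log units; within the scatter) show. This place has so far taken methyl, fluoro and nitro on the aromatic ring without any step beyond the scatter. Nothing available explains this flat response. From the compounds shown here alone, whether a 4-aminophenyl or 4-carboxyphenyl group here would also stay within the scatter remains open.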